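From pyridin-3-yl to 4-hydroxyphenyl on a shared core

The source may hold more compounds than are shown below. What is called first, only, known or untested is meant among the compounds shown, and "the series" means these compounds.

Of the compounds shown here, three sharing one core have been tested so far: compound 1 `COc1ccc(-c2noc(-c3ccncc3)n2)cc1OC1CCCC1`, compound 2 `COc1ccc(-c2noc(-c3ccc(F)cc3)n2)cc1OC1CCCC1` and compound 3 `COc1ccc(-c2noc(-c3cccnc3)n2)cc1OC1CCCC1`. In a functional assay on HCT-116 cells (Homo sapiens) for antiproliferative activity, read by MTT assay, with a stated time of 24 h (a lower number here means a stronger inhibitor, a higher number a weaker inhibitor), compound 3 gives > 1000000 nM, which is a limit of the assay and not a number. Compound 1 gives > 1000000 nM, which is also a limit. Compound 2, by contrast, gives a real number, 210000 nM.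

Compound 4 `COc1ccc(-c2noc(-c3ccc(O)cc3)n2)cc1OC1CCCC1` carries 4-hydroxyphenyl in place of the pyridin-3-yl of compound 3, on an aromatic carbon of a five-membered aromatic ring with 2 nitrogen and 1 oxygen: 4-hydroxyphenyl in place of pyridin-3-yl on an aromatic carbon. Among the measured compounds shown here, two measured steps bear on this change. The closer one is an at least 4.7-fold higher number from compound 2 to compound 3 (0.67 log units; beyond the scatter), with pyridin-3-yl in place of 4-fluorophenyl. The other is an at least 4.7-fold lower number from compound 1 to compound 2 (0.67 log units; beyond the scatter), with 4-fluorophenyl in place of pyridin-4-yl. Both steps are sized only through a limit, so their true size may be larger.

For the measured compounds named here, compound 4 shares with compound 2 a six-membered aromatic ring of carbon only, although no measured step tests the hydroxy group itself. A lower number in this assay is therefore expected, by a modest step or more. The expected step is an at least 5.0-fold lower number from compound 3 to compound 4 (0.69 log units; beyond the scatter). For compound 4 the estimated value is 200000 nM, with an expected range from 50000 nM to 800000 nM.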

Compound 4, half-maximal inhibitory concentration: 270 nM
Compound 4: the middle estimate sits 740-fold (2.87 log units) above what was measured; measured number outside the range, below it.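

Among the compounds shown here, the clearest reading comes from the one pair with two real numbers in this assay: fluoro and hydroxy on the same phenyl ring give a 780-fold lower number from compound 2 to compound 4 (2.89 log units; beyond the scatter), so the group carried by that ring matters far more here than the earlier compounds could show. Those compounds pointed only to an advantage of 4-fluorophenyl over pyridin-4-yl, with an at least 4.7-fold lower number from compound 1 to compound 2 (0.67 log units; beyond the scatter), whereas the fluoro and hydroxy compounds share a six-membered aromatic ring of carbon only and still lie far apart. The two other steps, an at least 3700-fold lower number from compound 3 to compound 4 (3.56 log units; beyond the scatter) and an at least 3700-fold lower number from compound 1 to compound 4 (3.56 log units; beyond the scatter), start from a limit and not a number, so their true size may be larger: the limit of > 1000000 nM in this assay, at which 2 of the 4 values shown sit.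

From the compounds shown here alone, with only fluoro and hydroxy compared on this phenyl ring, it stays open whether the hydroxy group is unusual or whether a methoxy group, an amine or a carboxylic acid in its place would do as well. Going by these compounds, it also stays open whether the hydroxy group would keep this effect on another carbon of the phenyl ring.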